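Furan for thiophene on a ribosylated core: three limits

A few compounds are considered here, and "the series" means these few. Any claim that something is new, unique, unknown or untested is made for them only; others in the source may bear on it.

Measured so far:
- compound 1 `Cc1ncnc2c1c(-c1ccoc1)cn2[C@@H]1O[C@H](CO)[C@@H](O)[C@H]1O` gives > 20000 nM in a functional assay on K562 cells (Homo sapiens), read by MTT assay, with a stated time of 72 h (on this read-out higher numbers stand for weaker inhibition and lower numbers for stronger inhibition), a limit of the assay rather than a number.
- compound 2 `Cc1ncnc2c1c(-c1cccs1)cn2[C@@H]1O[C@H](CO)[C@@H](O)[C@H]1O` gives > 20000 nM in this assay, again a limit rather than a number.
- compound 3 `Nc1nc(N)c2c(-c3cccs3)cn([C@@H]3O[C@H](CO)[C@@H](O)[C@H]3O)c2n1` gives > 20000 nM in this assay, also a limit rather than a number.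

Compound 2 and compound 1 share one core and differ by a single change, (furan-3-yl in place of thiophen-2-yl on an aromatic carbon). Because both values sit at a limit, the step that the two limits leave unreadable from compound 2 to compound 1 cannot be read: the change could have helped, hurt or done nothing, and the measurement would look the same. Compound 3 carries a different core, and the difference between the two cores is not broken down here.

Compound 4 `Nc1nc(N)c2c(-c3ccoc3)cn([C@@H]3O[C@H](CO)[C@@H](O)[C@H]3O)c2n1` has not yet been measured. It relates to compound 3 exactly as compound 1 relates to compound 2, through (furan-3-yl in place of thiophen-2-yl on an aromatic carbon), and the surroundings of the change are the same in both pairs, so it is the same change. For the measured compounds named here, the only evidence bearing on it is the limit of > 20000 nM in this assay, at which 3 of the 3 values shown sit, which tells that no compound here has yet produced a number.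

For compound 4 the step that the limit leaves unreadable from compound 3 to compound 4 is therefore expected to be small or unreadable, resting on the fact that compound 3 sits at a limit of > 20000 nM. The estimate for compound 4 in this assay is 30000 nM, with a range from 8000 nM to 150000 nM, and the outcome is expected most likely to be another limit.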

Compound 4, half-maximal inhibitory concentration: > 20000 nM
Compound 4 gave a limit, no number (the forecaster's own chance of this, stated with the estimate: 85%); the middle value lies beyond the limit too.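

Compound 3 and compound 4 both sit at a limit in this assay, so the step between them cannot be read, and no size can be given for furan-3-yl in place of thiophen-2-yl. The compounds shown leave open how strongly any of them inhibits and whether this change alters that at all, since the only evidence is a single limit: the limit of > 20000 nM in this assay, at which 4 of the 4 values shown sit.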